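The source may report more compounds than this note shows. Statements on the series, on what has been measured and on what is new or still open speak of the compounds shown alone.

Compound 1 `O=C1/C(=C/c2ccc([N+](=O)[O-])cc2)CCC/C1=C\c1cccc([N+](=O)[O-])c1` gives 17.9 ug/mL in a functional assay on SK-N-MC cells (Homo sapiens) for cytotoxicity, read by MTT assay (on this read-out lower numbers stand for stronger inhibition and higher numbers for weaker inhibition), the highest of the two numbers measured. Going by the values given here, compound 2 `O=C1/C(=C/c2cccc(Cl)c2)CCC/C1=C\c1cccc([N+](=O)[O-])c1` gives 4.15 ug/mL in this assay; the step of a 4.3-fold lower number from compound 1 to compound 2 (0.63 log units; beyond the scatter) is the only measured change. Compound 3 `COc1cccc(/C=C2\CCC/C(=C\c3ccc([N+](=O)[O-])cc3)C2=O)c1` differs from compound 1 by methoxy in place of nitro on an aromatic carbon. Among the compounds with values here, the one measured step alters the other aryl ring and another group, so it bears only loosely on this change. A modestly lower number, a 1.8-fold lower number from compound 1 to compound 3 (0.25 log units; within the scatter), is expected, leaning on the drop seen for compound 2 at 4.15 ug/mL. Compound 3 is therefore estimated at 10 ug/mL, with a range from 4 ug/mL to 25 ug/mL.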

Compound 3, half-maximal inhibitory concentration: 11.5 ug/mL
The estimate for compound 3 lay 1.2-fold (0.06 log units) below the measured number, within the range that was stated.
By their numbers in this assay, from the lowest: compound 2; then compounds 3 and 1 (each within the scatter of the next).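

In this assay, methoxy in place of nitro on this aromatic carbon gives a 1.6-fold lower number from compound 1 to compound 3 (0.19 log units; within the scatter) and leaves compound 1 and compound 3 within the scatter of each other. On this read-out, 3-nitrophenyl to 3-methoxyphenyl therefore shows no distinguishable change at this position, unlike the edit on the other aryl ring in compound 2. No supporting measurement bears on this result. From the compounds shown here alone, whether an amine or a carboxylic acid on this aromatic carbon would also stay within the scatter of compound 1 remains open. Also open, going by these compounds, is whether methoxy would give the same result alongside the 3-chlorophenyl of compound 2.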